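The source may report more compounds than this note shows. Statements on the series, on what has been measured and on what is new or still open speak of the compounds shown alone.

In an assay on mitochondria (strain BALB/c) for inhibition of glycerol-3-phosphate acyltransferase 1, mitochondrial (Mus musculus), read by scintillation counting, with a stated time of 10 min (on this read-out lower numbers stand for stronger inhibition and higher numbers for weaker inhibition), three compounds of one series have so far been measured. Compound 1 `CCCCCCCCS(=O)(=O)Nc1ccc(-c2ccc(Cl)cc2)cc1C(=O)O` gives 9200 nM, compound 2 `CCCCCCCCS(=O)(=O)Nc1ccc(-c2ccc(CCCC)cc2)cc1C(=O)O` gives 9000 nM, and compound 3 `CCCCCCCCS(=O)(=O)Nc1ccc(/C=C/c2ccccc2)cc1C(=O)O` gives 16300 nM, the highest of the three numbers, although its distances to the other two, a 1.8-fold higher number from compound 1 to compound 3 (0.25 log units; within the scatter) and a 1.8-fold higher number from compound 2 to compound 3 (0.26 log units; within the scatter), both fall within the scatter, so no order among them can be read from these values. Compound 4 `CCCCCCCCS(=O)(=O)Nc1ccc(/C=C/c2ccc(OC)cc2)cc1C(=O)O` differs from compound 3 by methoxy in place of hydrogen on an aromatic carbon. Among the measured compounds shown here, the only measured step that alters a group on the aromatic carbon para to a large group is a 1.0-fold lower number from compound 1 to compound 2 (0.01 log units; within the scatter), where one group replaced another without a change beyond the scatter; no measured step puts a group where a hydrogen stood. On that basis no step beyond the scatter is expected in this assay, in either direction, and the estimate for compound 4 is 16000 nM, with a range from 7000 nM to 36000 nM, which corresponds to an expected step of a 1.0-fold lower number from compound 3 to compound 4 (0.01 log units; within the scatter).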

Compound 4, half-maximal inhibitory concentration: 37100 nM
Beside the measured number, compound 4's estimate is 2.3-fold (0.37 log units) below it; the measured number lies above the stated range.
By their numbers in this assay, from the lowest: compounds 2, 1 and 3 (each within the scatter of the next); then compound 4.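

Methoxy in place of hydrogen on an aromatic carbon para to a large group gives a 2.3-fold higher number from compound 3 to compound 4 (0.36 log units; beyond the scatter) in this assay and so shows that this place can respond to a new group, in the direction of weaker inhibition, which the exchange of chloro for butyl had not shown. The other two comparisons, a 4.1-fold higher number from compound 2 to compound 4 (0.62 log units; beyond the scatter) and a 4.0-fold higher number from compound 1 to compound 4 (0.61 log units; beyond the scatter) also lie beyond the scatter, which makes compound 4 the weakest inhibitor of the four in this series. Nothing available explains this step.

The compounds shown leave open whether the loss belongs to methoxy itself or would also follow from another group here, such as fluoro, hydroxy, an amine or a carboxylic acid. They also leave open whether methoxy would act alike on the 4-chlorophenyl or 4-butylphenyl compounds.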